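This account rests on a few compounds, and the source may have more. Where it says the series, first, only, none or still open, it means among the compounds named here.

Of the compounds shown here, two have numbers so far. Compound 1 `CC1CCN(c2nc(C(F)(F)F)ccc2CNC(=O)C(c2ccc(NS(C)(=O)=O)c(F)c2)C2CCCCC2)CC1` gives 31.1 nM in an assay on CHO cells for antagonist activity at transient receptor potential cation channel subfamily V member 1 (Homo sapiens), read by FLIPR; on this read-out lower numbers stand for stronger inhibition and higher numbers for weaker inhibition. Compound 2 `CS(=O)(=O)Nc1ccc(C(C(=O)NCc2ccc(C(F)(F)F)nc2SC2CCCCC2)c2cccc(F)c2)cc1F`, which carries a cyclohexylthio group on the shared core and a 3-fluorophenyl on the saturated chain carbon, gives 48.7 nM in this assay; the gap to compound 1 lies within the usual scatter, so the two values are read as equivalent, and compound 2 is the only measured reference for the change that follows.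

Compound 3 `Cc1ccc(C(C(=O)NCc2ccc(C(F)(F)F)nc2SC2CCCCC2)c2ccc(NS(C)(=O)=O)c(F)c2)cc1` has not been measured. It differs from compound 2 in one place: 4-methylphenyl in place of 3-fluorophenyl on a saturated chain carbon bound to an aromatic carbon and a carbonyl carbon. The shared core, the cyclohexylthio group and the methanesulfonamide-bearing ring are unchanged. For the measured compounds named here, no measured pair isolates this kind of exchange, so there is no step to lean on. With the exchange confined to the aryl group on the saturated chain carbon and the rest of compound 2 retained, the step of a 1.0-fold higher number from compound 2 to compound 3 (0.01 log units; within the scatter) is expected to stay within the scatter, in no particular direction. For compound 3 the estimate in this assay is 50 nM, with a range from 18 nM to 140 nM.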

Compound 3, inhibition constant: 7.5 nM
Compound 3: the middle estimate sits 6.7-fold (0.82 log units) above what was measured; measured number below the stated range.
By their numbers in this assay, from the lowest: compound 3; then compounds 1 and 2 (each within the scatter of the next).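

The aryl group on the saturated chain carbon bound to an aromatic carbon and a carbonyl carbon matters in this assay: 4-methylphenyl in place of 3-fluorophenyl gives a 6.5-fold lower number from compound 2 to compound 3 (0.81 log units; beyond the scatter), a step beyond the scatter. The two groups match in what is counted for them: both have the same number of heavy atoms, a six-membered aromatic ring of carbon only, no hydrogen-bond donors or acceptors and no net charge. No measurement offered here accounts for the step, so it stands as an observation on this single exchange.

The exchange alters both the substituent and its place on the ring, and the compounds shown do not separate the two, so it remains open whether 3-methylphenyl or 4-fluorophenyl would read like compound 2 or like compound 3. Also open, on these data alone, are how 4-chlorophenyl or 4-methoxyphenyl would read on the same carbon, and whether the step would hold with a piperidine on the shared core in place of the cyclohexylthio group.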